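Amide Swap at the Carbonyl and What to Expect

The compounds below may be only part of what the source reports. "The series", "measured", "known", "first", "only" and "open" are said of these compounds alone.

Going by the values given here, compound 1 `COc1cc2c(cc1OC)C(CC(=O)N(C)C)CC2` gives 36% in a functional assay on the whole organism (strain Wistar) for inhibition, with Rattus norvegicus as the target, read by paw edema, with stated times of 60 min and 2 h, at a dose of 100 mg/kg by the oral route; on this read-out lower numbers stand for less inhibition and higher numbers for more inhibition at the one dose given (going by the name of the read-out); its only companion is compound 2 `CCCCCCNC(=O)CC1CCc2cc(OC)c(OC)cc21` with 41.5%, and the step of a number 5.5 percentage points higher from compound 1 to compound 2 (within the scatter) keeps the two within the scatter. Compound 3 `COc1cc2c(cc1OC)C(CC(=O)N1CCCC1)CC2` differs from compound 1 by pyrrolidin-1-yl in place of dimethylamino on a carbonyl carbon. Among the compounds with values here, the one measured step, hexylamino in place of dimethylamino on a carbonyl carbon, touches the same amide nitrogen and stayed within the scatter, so no step beyond the scatter is expected here, the estimated change being a number 2 percentage points higher from compound 1 to compound 3 (within the scatter). Compound 3 is therefore estimated at 38%, in a range from 26% to 50%.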

Compound 3, a percentage reported as inhibition, in the whole organism at one dose (the size of the read-out at that dose, not a potency): 20%
Compound 3: the middle estimate sits 18 percentage points above what was measured; the measured number lies below the stated range.
By their numbers in this assay, from the lowest: compound 3; then compounds 1 and 2 (each within the scatter of the next).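

In this assay, pyrrolidin-1-yl in place of dimethylamino on a carbonyl carbon gives a number 16 percentage points lower from compound 1 to compound 3 (beyond the scatter), and pyrrolidin-1-yl in place of hexylamino gives a number 21.5 percentage points lower from compound 2 to compound 3 (beyond the scatter). Going by these compounds alone, the read-out therefore does respond to the group at this place, which the pair with dimethylamino and hexylamino alone did not show, and the one group with a ring stands apart from the two without. Nothing given here explains this result.

Going by these compounds, whether piperidin-1-yl or morpholin-4-yl would follow pyrrolidin-1-yl, or diethylamino would follow dimethylamino, remains open.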